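Pyrrolidinyl for piperidinyl on the thiocarbonyl carbon

The compounds below may be only part of what the source reports. "The series", "measured", "known", "first", "only" and "open" are said of these compounds alone.

Compound 1 `Cc1ccc2c(=O)c(CSC(=S)N(C(C)C)C(C)C)coc2c1` is measured in a functional assay on MCF7 cells (Homo sapiens) for antiproliferative activity, read by MTT assay, with a stated time of 72 h (on this read-out lower numbers stand for stronger inhibition and higher numbers for weaker inhibition), and gives 6600 nM. Compound 2 `COc1ccc2occ(CSC(=S)N3CCCCC3)c(=O)c2c1` reaches only the limit of this assay, > 40000 nM, which is a limit and not a number; (the limit of > 40000 nM in this assay, at which 1 of the 2 values shown sits). Compound 3 `COc1ccc2occ(CSC(=S)N3CCCC3)c(=O)c2c1` differs from compound 2 by pyrrolidin-1-yl in place of piperidin-1-yl on a thiocarbonyl carbon. For the measured compounds named here, no measured step between compounds that differ in one place is at hand, so the expected step from compound 2 to compound 3 is a number no higher from compound 2 to compound 3 (the limit leaves the size open), nothing beyond the usual scatter. Compound 3 is therefore estimated at 40000 nM, within a range of 15000 nM to 100000 nM, and a limit is expected again in most runs.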

Compound 3, half-maximal inhibitory concentration: 34100 nM
Estimate against measurement, compound 3: 1.2-fold (0.07 log units) above; measured number inside the range.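

With pyrrolidin-1-yl on the thiocarbonyl carbon, compound 3 gives a measured number in this assay, 34100 nM, so this place in the series now has a value that is not a limit. As far as these compounds go, the step is an at least 1.1-fold lower number from compound 2 to compound 3 (0.06 log units; that floor lies within the scatter), and its true size stays open. Compound 2 remains a limit and not a number: the limit of > 40000 nM in this assay, at which 1 of the 3 values shown sits.

From the compounds shown here alone, whether morpholin-4-yl or a dimethylamino group on the thiocarbonyl carbon would give a lower number stays open. Going by these compounds, compound 1 differs from compound 2 and compound 3 in more than one place, so the separate contributions of its changes also stay open.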